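From the 4-methylpiperazin-1-yl chain to propyl

The compounds below may be only part of what the source reports. "The series", "measured", "known", "first", "only" and "open" are said of these compounds alone.

Within the data shown here, in a functional assay on cells (Homo sapiens) for antiproliferative activity, read by MTT assay, with a stated time of 48 h (on this read-out higher numbers stand for weaker inhibition and lower numbers for stronger inhibition), compound 2 (`CN1CCN(CCn2c(N)c(-c3nc4ccccc4[nH]3)c3nc(C#N)c(C#N)nc32)CC1`) gives 9110 nM, the only actual number so far. Compound 1 (`CCn1c(N)c(-c2nc3ccccc3[nH]2)c2nc(C#N)c(C#N)nc21`) gives > 50000 nM, which is a limit of the assay and not a number.

Compound 3 (`CCCn1c(N)c(-c2nc3ccccc3[nH]2)c2nc(C#N)c(C#N)nc21`) differs from compound 2 as follows: methyl in place of 4-methylpiperazin-1-yl on a saturated chain carbon, two bonds along the chain from an aromatic nitrogen. This is methyl in place of 4-methylpiperazin-1-yl on a saturated chain carbon, two bonds along the chain from an aromatic nitrogen, or, cut further out, 2-(4-methylpiperazin-1-yl)ethyl to propyl.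

Among the measured compounds shown here, one measured step bears on this change: an at least 5.4-fold lower number from compound 1 to compound 2 (0.73 log units; beyond the scatter). That step installs the same group at the same place, and the change to compound 3 removes it, leaving propyl where compound 1 carries ethyl. A higher number in this assay is therefore expected, reversing the step seen with compound 1, though that step has a limit at one end and gives no exact size. The expected shift is a 4.4-fold higher number from compound 2 to compound 3 (0.64 log units; beyond the scatter). For compound 3 the estimated value is 40000 nM, within an expected range of 15000 nM to 90000 nM, and a reading reported only as a limit is quite possible.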

Compound 3, half-maximal inhibitory concentration: > 50000 nM
Compound 3 ended at the assay's limit; the forecaster's own chance of this, stated with the estimate: 60%; at least 1.2-fold (0.09 log units) between middle value and limit.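

In this assay, methyl in place of 4-methylpiperazin-1-yl on the saturated chain carbon, two bonds along the chain from an aromatic nitrogen, gives an at least 5.4-fold higher number from compound 2 to compound 3 (0.73 log units; beyond the scatter). The 4-methylpiperazin-1-yl group now stands out against two simple chains, ethyl and propyl, and not against ethyl alone, so the earlier result, an at least 5.4-fold lower number from compound 1 to compound 2 (0.73 log units; beyond the scatter), no longer rests on a single partner. The step between the ethyl and propyl compounds cannot be read, and neither chain yields a number, because both sit at the assay's limit: the limit of > 50000 nM in this assay, at which 2 of the 3 values shown sit.

As far as these compounds go, the full size of the gain stays open, as both readable steps end at a limit, and a single terminal group cannot show whether the 4-methylpiperazin-1-yl ring itself matters or any amine at this place would serve. A morpholine or dimethylamino group on the same chain, or a longer chain carrying 4-methylpiperazin-1-yl, would address this.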